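Cytotoxicity of pyridazinone amides: a fluorophenyl swap

The source may report more compounds than this note shows. Statements on the series, on what has been measured and on what is new or still open speak of the compounds shown alone.

These notes cover two measured members of the series and one that is not yet measured. Compound 1 `CNC(=O)c1cc(Oc2ccc(NC(=O)c3nn(-c4cccc(F)c4)c(=O)cc3C)cc2F)ccn1` and compound 2 `Cc1cc(=O)n(-c2ccccc2OC(F)(F)F)nc1C(=O)Nc1ccc(Oc2ncnc3ccsc23)cc1` were tested in a functional assay on HepG2 cells (Homo sapiens) for cytotoxicity, read by MTT assay, with a stated time of 72 h; a lower number here means a stronger inhibitor, a higher number a weaker inhibitor. In this assay compound 1 gives 10200 nM. In this assay compound 2 gives 25000 nM, the highest of the two numbers; its nearest neighbour is compound 1, which lies beyond the scatter below it. The two compounds differ in several places at once, so their values are stated side by side without a single-change comparison.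

Compound 3 `Cc1cc(=O)n(-c2ccc(F)cc2)nc1C(=O)Nc1ccc(Oc2ncnc3ccsc23)cc1` is derived from compound 2 by one change, (4-fluorophenyl in place of 2-(trifluoromethoxy)phenyl on an aromatic nitrogen). Nothing measured in the series isolates this change. Both known values lie in the weak range, and the shared core is kept, so the expected step in this assay from compound 2 to compound 3 is small, in either direction, and within the scatter: a 1.4-fold lower number from compound 2 to compound 3 (0.14 log units; within the scatter). For compound 3 the estimate in this assay is 18000 nM, with a range from 6000 nM to 55000 nM.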

Compound 3, half-maximal inhibitory concentration: 2110 nM
Compound 3: middle estimate off by 8.5-fold (0.93 log units), on the high side; measured number outside the range, below it.
By their numbers in this assay, from the lowest: compound 3; then compound 1; then compound 2.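

In this assay, the aryl group on the aromatic nitrogen is now seen to matter on its own: with the rest of the structure kept, 4-fluorophenyl in place of 2-(trifluoromethoxy)phenyl gives a 12-fold lower number from compound 2 to compound 3 (1.07 log units; beyond the scatter) and the step is large. Among these compounds, compounds 1 and 2 differ in several places at once and could not show this, so the pair of compound 2 and compound 3 is the first single-change reading at this position, and it shows that the position is not silent in this cell read-out. The change alters several things together, as a group of 11 heavy atoms with 1 hydrogen-bond acceptor leaves and a group of 7 heavy atoms with none enters, and nothing available explains the step or ties it to any one of these differences.

On these data alone, with a single pair, it remains open whether the step comes from losing the 2-(trifluoromethoxy)phenyl or from gaining the 4-fluorophenyl, which a plain phenyl or a 4-chlorophenyl at this place would help to separate. As far as these compounds go, it is also open whether the same swap gives a step of similar size on the core of compound 1.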